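Adding a phenyl group to the ring nitrogen of compound 1

The source may hold more compounds than are shown below. What is called first, only, known or untested is meant among the compounds shown, and "the series" means these compounds.

Compound 1, `Cc1[nH]c(C(F)(F)F)cc1C(=O)O`, is a small acid on a five-membered aromatic core. Within the data shown here, in an assay on cells for inhibition of Palmitoleoyl-protein carboxylesterase NOTUM variant C330S (Homo sapiens), read by fluorescence, with a stated time of 40 min (a higher number here means a weaker inhibitor, a lower number a stronger inhibitor), compound 1 gives 6700 nM, and this is the only actual number in the set. Compound 2, `Cc1cc(C(=O)O)c(C)[nH]1`, differs by carrying a methyl where compound 1 carries a trifluoromethyl. For compound 2 this assay reports only a limit, > 100000 nM, so its true value is not known. The step of an at least 14-fold higher number from compound 1 to compound 2 (1.17 log units; beyond the scatter) therefore shows that the trifluoromethyl matters for potency here, with the reading for compound 2 sitting at the limit of > 100000 nM in this assay, at which 1 of the 2 values shown sits.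

Compound 3, `Cc1c(C(=O)O)cc(C(F)(F)F)n1-c1ccccc1`, is made from compound 1 by the change (phenyl in place of hydrogen on an aromatic nitrogen). Among the measured compounds shown here, no measured step covers this kind of change; the only measured step concerns a group on a ring carbon, not the ring nitrogen, so it gives no direct guidance. The trifluoromethyl and the acid are kept. On that basis compound 3 is expected to reach roughly 2000 nM in this assay, within a range of 300 nM to 15000 nM, meaning an estimated step of a 3.4-fold lower number from compound 1 to compound 3 (0.53 log units; beyond the scatter).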

Compound 3, half-maximal inhibitory concentration: 22000 nM
Estimate against measurement, compound 3: 11-fold (1.04 log units) below, and the stated range ends below it.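

In this assay, the first change shown at the ring nitrogen moves potency the wrong way: swapping its hydrogen for phenyl gives a 3.3-fold higher number from compound 1 to compound 3 (0.52 log units; beyond the scatter). The earlier pair spoke only about a group on a ring carbon, whereas this result shows that the ring nitrogen also affects potency, and that the hydrogen on it is preferred over phenyl in this series, although the loss is modest and compound 3 still gives a real number rather than a limit. Nothing shown here explains why phenyl lowers potency, so this result records the size of the effect but not its cause.

Going by these compounds, with only one substituent tested at this nitrogen, it remains open whether the loss applies to anything placed there or is specific to phenyl, and a small methyl, a longer chain such as butyl, or a benzyl group at the same position would help separate those possibilities. On these data alone, it is equally open whether a substituent on the phenyl ring itself, such as an amine or a fluorine, could recover the potency of compound 1.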